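Swapping a Chlorophenyl Carbonyl for an Acetyl Group

The source may report more compounds than this note shows. Statements on the series, on what has been measured and on what is new or still open speak of the compounds shown alone.

Four compounds share a bicyclic core carrying an amide on one side and an acyl group on the ring nitrogen on the other. Compound 1 is `CC(=O)N1c2ccccc2CCC1C(=O)Nc1ccccc1O`, compound 2 is `O=C(Nc1ccccc1O)C1CCc2ccccc2N1C(=O)c1ccc(Cl)cc1` and compound 3 is `O=C(Nc1ccccc1C(F)(F)F)C1CCc2ccccc2N1C(=O)c1ccc(Cl)cc1`. The unmeasured compound 4 is `CC(=O)N1c2ccccc2CCC1C(=O)Nc1ccccc1C(F)(F)F`.

In a functional assay on MDA-MB-231 cells (Homo sapiens) for cytotoxicity, read by sulforhodamine B assay, with a stated time of 72 h (a higher number here means a weaker inhibitor of growth, a lower number a stronger inhibitor of growth), compound 1 gives 89600 nM. In this assay compound 2 gives 19600 nM, and compound 3 gives 533 nM, the lowest of the three numbers. Going from compound 2 to compound 3 the change is trifluoromethyl in place of hydroxy on an aromatic carbon, and the step is a 37-fold lower number from compound 2 to compound 3 (1.57 log units; beyond the scatter). Going from compound 2 to compound 1 the change is methyl in place of 4-chlorophenyl on a carbonyl carbon, and the step is a 4.6-fold higher number from compound 2 to compound 1 (0.66 log units; beyond the scatter).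

Compound 4 differs from compound 3 by methyl in place of 4-chlorophenyl on a carbonyl carbon. This is the same change already seen between compound 2 and compound 1, at the same place, but now on the core of compound 3 rather than of compound 2; the two cores differ by trifluoromethyl in place of hydroxy on an aromatic carbon.

Because the step of a 4.6-fold higher number from compound 2 to compound 1 (0.66 log units; beyond the scatter) was modest and in the weakening direction, a step of similar size is expected here, estimated as a 4.7-fold higher number from compound 3 to compound 4 (0.67 log units; beyond the scatter). Within the data shown here, compound 4 is therefore expected to give about 2500 nM, with a plausible range from 800 nM to 8000 nM, since only one prior example of this change is available.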

Compound 4, concentration for 50% growth inhibition: > 80000 nM
Compound 4 was reported as a limit; the forecaster's own chance of this, stated with the estimate: 5%; at least 32-fold (1.50 log units) between middle value and limit.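

In this assay compound 4 gives > 80000 nM, which is a limit of the assay and not a number.

Methyl in place of 4-chlorophenyl on the carbonyl carbon raises the number on both cores, but the step on the trifluoromethyl core, an at least 150-fold higher number from compound 3 to compound 4 (2.17 log units; beyond the scatter), is much larger than the one on the hydroxy core, so the size of this change does not carry over from one core to the other: the same change on two cores in this assay, a 4.6-fold higher number (0.66 log units; beyond the scatter) from compound 2 to compound 1 and an at least 150-fold higher number (2.17 log units; beyond the scatter) from compound 3 to compound 4, at least 32-fold (1.51 log units) apart, beyond the scatter of two such steps. What this does not show is the true size of the step to compound 4, since only its lower bound can be read, and the step from compound 1 to compound 4, where trifluoromethyl replaces hydroxy, cannot be read at all.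

Among these compounds, with only two pairs of compounds, this difference describes these four compounds and is no rule for the series, and the data give no reason for it. Going by these compounds, only 4-chlorophenyl and methyl appear on the carbonyl carbon, so it remains open how an unsubstituted phenyl or a longer chain such as propyl would behave there, and whether a nitrile or a carboxylic acid in place of trifluoromethyl would change the picture.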